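Chloro for fluoro on two related cores: working notes

The source may report more compounds than this note shows. Statements on the series, on what has been measured and on what is new or still open speak of the compounds shown alone.

All three measured compounds were tested in an assay on isolated protein for inhibition of protein deacetylase HDAC6 (Homo sapiens), read by fluorescence, with a stated time of 2 h; on this read-out higher numbers stand for weaker inhibition and lower numbers for stronger inhibition; in each case the assay returned a limit rather than a number.

compound 1 `CCCNNC(=O)c1ccc(CNC(=O)c2cc3cc(F)ccc3[nH]2)cc1`: > 10000 nM
compound 2 `CCCNNC(=O)c1ccc(CNC(=O)c2cc3cc(Cl)ccc3[nH]2)cc1`: > 10000 nM
compound 3 `CCCNNC(=O)c1ccc(CNC(=O)c2cc3cc(F)ccc3o2)cc1`: > 10000 nM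

Compound 1 sits at a limit of this assay, > 10000 nM. Compound 2 carries chloro in place of fluoro on an aromatic carbon relative to compound 1. Compound 2 likewise sits at a limit, > 10000 nM. The step that the two limits leave unreadable from compound 1 to compound 2 therefore cannot be sized, because of the limit of > 10000 nM in this assay, at which 3 of the 3 values shown sit; both ends of the step rest at the same limit.

Compound 3 differs from compound 1 in its core; the difference between the two cores is not broken down here. Compound 3 also sits at a limit, > 10000 nM.

Compound 4 `CCCNNC(=O)c1ccc(CNC(=O)c2cc3cc(Cl)ccc3o2)cc1` has not yet been measured in this assay. Relative to compound 3 it carries chloro in place of fluoro on an aromatic carbon, the same change as that from compound 1 to compound 2, at the same place on the ring. Going by the values given here, since the only measured instance of this change left both compounds at the limit, and since compound 3 itself returns only > 10000 nM, the step that the limit leaves unreadable from compound 3 to compound 4 is expected to leave compound 4 at or near the limit as well. Compound 4 is estimated at 20000 nM in this assay, with an expected range of 8000 nM to 60000 nM, and most likely reported again as a limit.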

Compound 4, half-maximal inhibitory concentration: > 10000 nM
Compound 4 was reported as a limit; the forecaster's own chance of this, stated with the estimate: 85%; the middle value is on the limit's open side.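

In this assay compound 4 gives > 10000 nM and this is a limit of the assay. No step can be read from compound 3 to compound 4, and all values remain at one limit: the limit of > 10000 nM in this assay, at which 4 of the 4 values shown sit.

The compounds shown leave open whether chloro in place of fluoro changes inhibition on either core, and how strongly any of the four compounds inhibits.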